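The compounds below may be only part of what the source reports. "The series", "measured", "known", "first", "only" and "open" are said of these compounds alone.

Working notes on the series. Compound 1 `CC1=C(C(=O)C2CC2)C(c2ccco2)NC(=O)N1` is the reference point: in an assay on membranes from CHO cells for displacement of a labelled ligand from adenosine receptor A1 (Homo sapiens), read by scintillation counting, with a stated time of 60 min, tested at 1 uM (on this read-out lower numbers stand for less inhibition and higher numbers for more inhibition at the one concentration tested (going by the name of the read-out)), compound 1 gives 2%. Compound 2 `CCCC(=O)C1=C(C)NC(=O)NC1c1ccco1` differs from compound 1 by propyl in place of cyclopropyl on a carbonyl carbon. In this assay compound 2 gives 1%, the step being a number 1 percentage points lower from compound 1 to compound 2 (within the scatter). Compound 3 `CC1=C(C(=O)C2CC2)C(c2cccs2)NC(=O)N1` carries the other variation; in this assay compound 3 gives 1%, the step being a number 1 percentage points lower from compound 1 to compound 3 (within the scatter). Among the compounds with values here, compound 3 and compound 2 stand level at the digits read, and together they are the lowest of the three numbers, though no step among the three lies beyond the scatter. The core of compound 3 differs from the core of compound 1 by thiophen-2-yl in place of furan-2-yl on a saturated ring carbon.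

Compound 4 `CCCC(=O)C1=C(C)NC(=O)NC1c1cccs1` is not yet measured. It differs from compound 3 by propyl in place of cyclopropyl on a carbonyl carbon, the same change that is made from compound 1 to compound 2; the change occurs twice among these compounds, and the two place descriptions read the same word for word. The step from compound 3 to compound 4 is expected at no change at the digits printed from compound 3 to compound 4 (within the scatter), beside the earlier a number 1 percentage points lower from compound 1 to compound 2 (within the scatter), which rests on that earlier step lying within the scatter and on the uniformly low numbers of compound 1, compound 2 and compound 3. Compound 4 is accordingly estimated at 1%, expected to fall between -6% and 9%.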

Compound 4, a percentage reported as inhibition, at one concentration (the size of the read-out at that concentration, not a potency): 2%
Compound 4: middle estimate off by 1 percentage points, on the low side; the range from low to high includes it.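

In this assay, propyl in place of cyclopropyl on a carbonyl carbon gives a number 1 percentage points higher from compound 3 to compound 4 (within the scatter), and beside the earlier step on the core of compound 1 the change shows no difference between cores: the same change on two cores in this assay, a number 1 percentage points lower (within the scatter) from compound 1 to compound 2 and a number 1 percentage points higher (within the scatter) from compound 3 to compound 4, 2 percentage points apart, within the scatter of two such steps. Thiophen-2-yl in place of furan-2-yl on a saturated ring carbon gives a number 1 percentage points higher from compound 2 to compound 4 (within the scatter), and this change likewise shows no difference between cores: the same change on two cores in this assay, a number 1 percentage points lower (within the scatter) from compound 1 to compound 3 and a number 1 percentage points higher (within the scatter) from compound 2 to compound 4, 2 percentage points apart, within the scatter of two such steps. This shows that neither change moves the read-out beyond the scatter on either core at the one concentration tested, but it does not show that a real effect of either change carries from one core to another, as all the steps compared lie within the scatter.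

The compounds shown leave open whether a different group on the carbonyl carbon or the saturated ring carbon, such as an amine, a carboxylic acid or a longer chain, would give a step beyond the scatter. They also leave open whether such a step would carry from one core to another.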